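Hydroxy to methoxy on compound 1: expected step

The source may hold more compounds than are shown below. What is called first, only, known or untested is meant among the compounds shown, and "the series" means these compounds.

Measured so far in an ADME assay on HEK293 cells (Homo sapiens) for inhibition, read by MTT assay, with a stated time of 2 days; on this read-out higher numbers stand for weaker inhibition and lower numbers for stronger inhibition:
compound 1 `Oc1cccc(/C=C/c2cccc(O)c2)c1` gives 21 ug/mL
compound 2 `COc1ccc(/C=C/c2ccccc2O)cc1` gives 21 ug/mL
compound 3 `Nc1ccc(/C=C/c2ccccc2O)cc1` gives 21.4 ug/mL

Compound 1 stands level with compound 2 at the digits reported, and compound 3 lies within the scatter of both, so these values set no order among the three. Compound 4 `COc1cccc(/C=C/c2cccc(O)c2)c1` is still unmeasured. Its change from compound 1, methyl in place of hydrogen on an oxygen on an aromatic ring in the counted form, is methyl in place of hydrogen on an oxygen on an aromatic ring, or hydroxy to methoxy. Among the compounds with values here, no measured pair shows this same change. Within the data shown here, the one measured single-place step a 1.0-fold higher number from compound 2 to compound 3 (0.01 log units; within the scatter) is amino in place of methoxy on an aromatic carbon and stays within the scatter, so no shift beyond the scatter is expected in this assay in either direction, although this is thin evidence. The expected step is a 1.1-fold lower number from compound 1 to compound 4 (0.02 log units; within the scatter) at the middle of the estimate. For compound 4 the estimate is 20 ug/mL with an expected range from 10 ug/mL to 40 ug/mL for the measurement.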

Compound 4, half-maximal inhibitory concentration: 19 ug/mL
Beside the measured number, compound 4's estimate is 1.1-fold (0.02 log units) above it, within the range that was stated.
By their numbers in this assay, from the lowest: compounds 4, 1, 2 and 3 (each within the scatter of the next).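

In this assay, methyl in place of hydrogen on an oxygen on an aromatic ring gives a 1.1-fold lower number from compound 1 to compound 4 (0.04 log units; within the scatter). Within the data shown here, this is the first direct reading of hydroxy to methoxy, and at this place on the core of compound 1 the change shows no shift beyond the scatter, so the hydrogen on this oxygen is not needed to keep the number in the range of compound 1. Nothing available bears on the reason for this outcome.

The compounds shown leave open whether the remaining hydroxy of compound 4 tolerates the same change. They also leave open whether a longer chain on this oxygen, such as ethyl, or a carboxylic acid in place of the methyl, would stay within the scatter of compound 1 in this assay.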